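Shortening the ketone chain to an amide at the shared core

The source may hold more compounds than are shown below. What is called first, only, known or untested is meant among the compounds shown, and "the series" means these compounds.

Three measured compounds share one core and differ only at its edges. Compound 1 `CCCC(=O)C1=C(C)NC(=O)NC1c1ccoc1` gives 22% in an assay on membranes from HEK293 cells for displacement of a labelled ligand from adenosine receptor A2b (Homo sapiens), read by scintillation counting, with a stated time of 30 min, tested at 1 uM (a lower number here means less inhibition, a higher number more inhibition at the concentration tested (going by the name of the read-out)), compound 2 `CC(=O)C1=C(C)NC(=O)NC1c1ccsc1` gives 24%, and compound 3 `CCCC(=O)C1=C(C)NC(=O)NC1c1ccsc1` gives 9%, the lowest of the three: the thiophene ring gave a number 13 percentage points lower from compound 1 to compound 3 (beyond the scatter), and a longer chain on the ketone gave a number 15 percentage points lower from compound 2 to compound 3 (beyond the scatter). Compound 4 `CC1=C(C(N)=O)C(c2ccsc2)NC(=O)N1` has amino in place of propyl on a carbonyl carbon. For the measured compounds named here, only the step to compound 3 from compound 2 bears on this change, since it also shortens the chain at the carbonyl; it was modest in size, and in that direction. A modest rise is therefore expected, a number 11 percentage points higher from compound 3 to compound 4 (beyond the scatter). Compound 4 is estimated at 20%, between 5% and 40%.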

Compound 4, a percentage reported as inhibition, at one concentration (the size of the read-out at that concentration, not a potency): 1%
Compound 4: the middle estimate sits 19 percentage points above what was measured, and the stated range ends above it.
By their numbers in this assay, from the lowest: compounds 4 and 3 (each within the scatter of the next); then compounds 1 and 2 (each within the scatter of the next).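

In this assay, amino in place of propyl on the carbonyl carbon gave a number 8 percentage points lower from compound 3 to compound 4 (within the scatter) and so cannot be told apart from propyl here. Set against the shorter methyl ketone, amino gave a number 23 percentage points lower from compound 2 to compound 4 (beyond the scatter) and so shows that a smaller group at this carbonyl carbon does not by itself keep the higher number. Nothing available explains this result. Still open, on these data alone, is how a methylamino or dimethylamino group on this carbonyl carbon would read, and how a carboxylic acid would compare with the amide.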